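Aryl Ester Series: Trifluoromethyl for Methoxy on Compound 2

This account rests on a few compounds, and the source may have more. Where it says the series, first, only, none or still open, it means among the compounds named here.

Measured compounds:
compound 1 `COc1ccc(C(=O)Oc2cc3c(cc2C)[C@@H](C(C)C)CC=C3C)cc1` — 37%
compound 2 `COc1cccc(C(=O)Oc2cc3c(cc2C)[C@@H](C(C)C)CC=C3C)c1` — "not active" (no number reported)

In a functional assay on U-251 cells (Homo sapiens) for antiproliferative activity, read by sulforhodamine B assay, with a stated time of 48 h, tested at 50 uM (a higher number here means more inhibition at the concentration tested (going by the name of the read-out), a lower number less inhibition), compound 1 gives 37%. Compound 2 is recorded in this assay only as "not active" (no number reported), so no single number places it; it sits below compound 1 by an amount that cannot be stated.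

Compound 3 `CC1=CC[C@H](C(C)C)c2cc(C)c(OC(=O)c3cccc(C(F)(F)F)c3)cc21` follows compound 2 through (trifluoromethyl in place of methoxy on an aromatic carbon). Among the measured compounds shown here, no measured step of this kind exists, so no direction or size is given; a change of any size would be an expectation only.

Compound 3 is estimated at 15% in this assay, with an expected range from 0% to 40%.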

Compound 3, a percentage reported as inhibition, at one concentration (the size of the read-out at that concentration, not a potency): 29.3%
Compound 3: the middle estimate sits 14.3 percentage points below what was measured; the measured number falls inside the stated range.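

Among the compounds shown here, compound 2 has no number in this assay and compound 3 does, so no step from compound 2 to compound 3 can be read. The compounds shown leave open how trifluoromethyl compares with methoxy at that place. No supporting evidence bears on this result.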